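Working notes: changing the group on the carbonyl carbon

The compounds below may be only part of what the source reports. "The series", "measured", "known", "first", "only" and "open" are said of these compounds alone.

Measured so far:
compound 1 `COc1cc(NC(C)CCCNC(=O)NCc2ccncc2)c2ncccc2c1`: 20000 nM
compound 2 `COc1cc(NC(C)CCCNC(=O)NC2CCCC2)c2ncccc2c1`: 19000 nM
compound 3 `COc1cc(NC(C)CCCNC(=O)NC2CCCCC2)c2ncccc2c1`: 38000 nM

All three compounds were run in a functional assay on MIA PaCa-2 cells (Homo sapiens), read by MTT assay, with a stated time of 72 h; a higher number here means a weaker inhibitor, a lower number a stronger inhibitor. Compound 1 gives 20000 nM; its nearest neighbour is compound 2 with a 1.1-fold lower number from compound 1 to compound 2 (0.02 log units; within the scatter), and its furthest is compound 3 with a 1.9-fold higher number from compound 1 to compound 3 (0.28 log units; within the scatter). Between the other two, a 2.0-fold higher number from compound 2 to compound 3 (0.30 log units; within the scatter). Every step measured so far is within the scatter, so the three numbers cannot be told apart and compound 1 simply sits among them.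

Compound 4 `COc1cc(NC(C)CCCNC(=O)n2nnc3ccccc32)c2ncccc2c1` is the next member. It differs from compound 1 in this way: a group of 9 heavy atoms (6 carbon, 3 nitrogen; one five-membered aromatic ring with 3 hetero atoms, one six-membered aromatic ring of carbon only) in place of a group of 8 heavy atoms (6 carbon, 2 nitrogen; one six-membered aromatic ring with 1 hetero atom), on a carbonyl carbon. The three known steps all exchange one group on the amide-type nitrogen for another and none moved the number beyond the scatter; the change to compound 4 instead replaces the whole group on the carbonyl carbon, so those steps bear on it only loosely. Going by the values given here, with no step beyond the scatter, the expectation for compound 4 is a number near that of compound 1, with a 1.3-fold higher number from compound 1 to compound 4 (0.10 log units; within the scatter) judged likely to stay within the scatter, while the wider change leaves more room for a miss either way. The estimate for compound 4 is therefore 25000 nM, in a range from 8000 nM to 80000 nM.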

Compound 4, half-maximal inhibitory concentration: 84000 nM
The estimate for compound 4 lay 3.4-fold (0.53 log units) below the measured number; the measured number lies above the stated range.
By their numbers in this assay, from the lowest: compounds 2, 1 and 3 (each within the scatter of the next); then compound 4.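

In this assay, going by these compounds alone, the group on the carbonyl carbon is the first place where an exchange goes beyond the scatter: replacing ((pyridin-4-yl)methyl)amino with the group bearing a five-membered aromatic ring with 3 hetero atoms and a six-membered aromatic ring of carbon only gives a 4.2-fold higher number from compound 1 to compound 4 (0.62 log units; beyond the scatter). The cyclic members point the same way, with a 4.4-fold higher number from compound 2 to compound 4 (0.65 log units; beyond the scatter) and a 2.2-fold higher number from compound 3 to compound 4 (0.34 log units; beyond the scatter), so compound 4 is the weakest of the four and the modest loss holds against all three groups that could not be told apart. By count, the change also takes the group from 1 hydrogen-bond donor to 0 and from 1 hydrogen-bond acceptor to 3, but no measurement shown links either count or the ring change to the higher number.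

As far as these compounds go, whether the higher number follows the missing amide hydrogen or the fused aromatic rings stays open, as compound 4 changes both at once. A piperidin-1-yl group on the carbonyl carbon, which has no amide hydrogen and no aromatic ring, or a benzylamino group, which keeps that hydrogen and has an aromatic ring, would begin to separate the two.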